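Ester to ketone on the shared core: compound 4

A few compounds are considered here, and "the series" means these few. Any claim that something is new, unique, unknown or untested is made for them only; others in the source may bear on it.

Measured so far in a functional assay on 786-0 cells (Homo sapiens) for inhibition, read by sulforhodamine B assay, with a stated time of 48 h; on this read-out lower numbers stand for stronger inhibition of growth and higher numbers for weaker inhibition of growth:
compound 1, `C=C(C)[C@@H]1CC=C(Cn2cc(COc3cccc(C4NC(=O)NC(C)=C4C(=O)OCC)c3)nn2)CC1`, gives 39700 nM.
compound 3, `C=C(C)[C@@H]1CC=C(Cn2cc(COc3ccc(C4NC(=O)NC(C)=C4C(C)=O)cc3)nn2)CC1`, gives 23300 nM.
compound 2, `C=C(C)[C@@H]1CC=C(Cn2cc(COc3cc(C4NC(=O)NC(C)=C4C(=O)OCC)ccc3OC)nn2)CC1`, gives a value that is a limit of the assay, > 100000 nM.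

Among the numbers shown, compound 1 stands highest of the two that are numbers; compound 3 sits nearest with a number that is within the usual scatter of compound 1, so the two are not set apart. Among the measured compounds shown here, the one step measured with a single change, an at least 2.5-fold higher number from compound 1 to compound 2 (0.40 log units; beyond the scatter), lies beyond the scatter, and what bears on it is the limit of > 100000 nM in this assay, at which 1 of the 3 values shown sits.

Compound 4, `C=C(C)[C@@H]1CC=C(Cn2cc(COc3cccc(C4NC(=O)NC(C)=C4C(C)=O)c3)nn2)CC1`, differs from compound 1 by methyl in place of ethoxy on a carbonyl carbon. For the measured compounds named here, no measured step isolates this change: compound 3 carries the same methyl ketone but differs from compound 1 in more than one place, so its value shows only that such a ketone can sit on the core without any shift beyond the scatter. Compound 4 is therefore expected to give about 32000 nM, between 11000 nM and 95000 nM, and the step of a 1.2-fold lower number from compound 1 to compound 4 (0.09 log units; within the scatter) is expected to stay within the scatter.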

Compound 4, concentration for total growth inhibition: 44100 nM
Beside the measured number, compound 4's estimate is 1.4-fold (0.14 log units) below it, and the stated range covers the measured number.
By their numbers in this assay, from the lowest: compounds 3, 1 and 4 (each within the scatter of the next). At a limit, above all of these: compound 2.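

In this assay, the change of ethoxy to methyl on the carbonyl carbon now stands alone and gives a 1.1-fold higher number from compound 1 to compound 4 (0.05 log units; within the scatter) on the shared core. The earlier compounds shown here held the acetyl group only together with a further difference, whereas this pair shows that ethoxycarbonyl and acetyl are not set apart at this position. The ethoxy is thus not needed to keep the number at this level, and nothing measured here bears on why the change leaves it in place.

The compounds shown leave open whether an amine, a carboxylic acid or a longer chain on this carbonyl carbon would also stay within the scatter. They also leave open whether any group here would bring the number down beyond the scatter.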